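Thiophen-3-yl in Place of Isopropyl: An Expected Step

A few compounds are considered here, and "the series" means these few. Any claim that something is new, unique, unknown or untested is made for them only; others in the source may bear on it.

Of the compounds shown here, three sharing one core have been measured in an assay on HEK293 cells for binding affinity to 5-hydroxytryptamine receptor 7 (Homo sapiens), read by radioligand binding, tested at 1 uM; a lower number here means less inhibition, a higher number more inhibition at the concentration tested (going by the name of the read-out). Compound 1 `CN1CCCN(CCn2ccc3ccc(Cl)cc32)CC1` gives 85%. Compound 2 `CN1CCCN(CCn2ccc3ccc(C(N)=O)cc32)CC1` gives 33%. Compound 3 `CC(C)c1ccc2ccn(CCN3CCCN(C)CC3)c2c1` gives 72%. Within this set compound 3 stands second highest of the three: the step of a number 13 percentage points lower from compound 1 to compound 3 (beyond the scatter) is modest, while the step of a number 39 percentage points higher from compound 2 to compound 3 (beyond the scatter) is large. The carbamoyl compound sits lowest of all, the step of a number 52 percentage points lower from compound 1 to compound 2 (beyond the scatter) being large.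

Compound 4 `CN1CCCN(CCn2ccc3ccc(-c4ccsc4)cc32)CC1` has not yet been measured in this assay. It differs from compound 3 at one place: thiophen-3-yl in place of isopropyl on an aromatic carbon. For the measured compounds named here, none of the measured steps exchanges a substituent on that aromatic carbon for a ring, so no step bears on it directly. What the measured steps show is that the position takes a chloro and an isopropyl group with high inhibition and a carbamoyl group with far lower inhibition. Thiophen-3-yl is neither of these, and the expected step is a number 2 percentage points lower from compound 3 to compound 4 (within the scatter), with the wide range reflecting how little the measured pairs say about an aromatic ring at this place. Compound 4 is therefore estimated at 70%, within a range from 45% to 90%.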

Compound 4, a percentage reported as inhibition, at one concentration (the size of the read-out at that concentration, not a potency): 68%
The estimate for compound 4 lay 2 percentage points above the measured number, within the range that was stated.
By their numbers in this assay, from the lowest: compound 2; then compounds 4 and 3 (each within the scatter of the next); then compound 1.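

In this assay the position proves to take an aromatic ring as well as it takes an open alkyl group: thiophen-3-yl, with 5 heavy atoms and one hydrogen-bond acceptor, in place of isopropyl, with 3 heavy atoms and none, gives a number 4 percentage points lower from compound 3 to compound 4 (within the scatter) and so leaves the read-out unmoved. The same ring stands far from the carbamoyl group, at a number 35 percentage points higher from compound 2 to compound 4 (beyond the scatter), and short of the chloro group, at a number 17 percentage points lower from compound 1 to compound 4 (beyond the scatter), so that compound 1 keeps the highest number of the four and the larger substituent does not close the gap to it. Nothing at hand explains any of these differences.

Open, going by these compounds, is whether thiophen-2-yl, phenyl or a pyridyl ring would hold the read-out at the level of thiophen-3-yl, and whether a primary amine or a carboxylic acid at this place would fall as low as the carbamoyl group of compound 2. Also open, on these data alone, is whether chloro, isopropyl and thiophen-3-yl would keep this order at another aromatic carbon of the shared core.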